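Amino Replacing Hydrogen on the Shared Core

This account rests on a few compounds, and the source may have more. Where it says the series, first, only, none or still open, it means among the compounds named here.

Measured compounds:
Compound 1, `C[C@@H]1CCCN1c1c(C#N)c2c(N)nc(Nc3cn[nH]c3)nc2n1C` — 6 nM in an assay on isolated protein for inhibition of Leucine-rich repeat serine/threonine-protein kinase 2 variant G2019S (Homo sapiens), read by TR-FRET and LanthaScreen, with stated times of 50 min and 30 min, in the presence of a further agent that is not named here; a higher number here means a weaker inhibitor, a lower number a stronger inhibitor
Compound 2, `C[C@@H]1CCCN1c1c(C#N)c2c(N)ncnc2n1C` — 11 nM in this assay

Compound 2 holds the highest of the two numbers in this assay; its nearest neighbour is compound 1, and the step of a 1.8-fold higher number from compound 1 to compound 2 (0.26 log units; within the scatter) lies within the scatter of the assay. For the measured compounds named here, the only measured step therefore shows that removing the (1H-pyrazol-4-yl)amino group from the aromatic carbon left the number essentially unchanged.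

Compound 3, `C[C@@H]1CCCN1c1c(C#N)c2c(N)nc(N)nc2n1C`, is not yet measured. It differs from compound 2 by amino in place of hydrogen on an aromatic carbon. This change sits at the same aromatic carbon that the step from compound 1 to compound 2 altered, and that step a 1.8-fold higher number from compound 1 to compound 2 (0.26 log units; within the scatter) is the only one bearing on it. Since a far larger group at that carbon produced no step beyond the scatter, a small amino group is expected to produce none either, and the step of a 1.2-fold lower number from compound 2 to compound 3 (0.09 log units; within the scatter) is estimated to stay within the scatter. Compound 3 is therefore expected to give about 9 nM in this assay, with a likely range from 4 nM to 25 nM.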

Compound 3, half-maximal inhibitory concentration: 217 nM
Estimate against measurement, compound 3: 24-fold (1.38 log units) below; measured number outside the range, above it.
By their numbers in this assay, from the lowest: compounds 1 and 2 (each within the scatter of the next); then compound 3.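

Amino in place of hydrogen on the aromatic carbon between two ring nitrogen atoms gives a 20-fold higher number from compound 2 to compound 3 (1.30 log units; beyond the scatter) in this assay, so this position is not indifferent to what it carries, as the step between compound 1 and compound 2 alone had suggested. The nitrogen on that carbon does not act the same way in every compound: hydrogen in place of 1H-pyrazol-4-yl on it gives a 36-fold higher number from compound 1 to compound 3 (1.56 log units; beyond the scatter) and leaves the free amino group as the outlier of the three. Group size does not order these numbers, since compound 3, with the single added heavy atom, stands apart, whereas compound 1, with the much larger group, lies within the scatter of compound 2. The data shown offer no measurement that explains this behaviour.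

From the compounds shown here alone, whether the number recovers only with 1H-pyrazol-4-yl on that nitrogen remains open, as a methyl group, an acetyl group or a phenyl ring there could behave like either extreme. Going by these compounds, it is equally open whether a methyl group or a chlorine atom on the same carbon would track hydrogen or amino.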